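Quaternary ammonium tail swap across two aryl ether cores

The source may report more compounds than this note shows. Statements on the series, on what has been measured and on what is new or still open speak of the compounds shown alone.

Of the compounds shown here, three have been measured in an assay on LX2 cells for inhibition of COL1A1 promoter (Homo sapiens), read by a luciferase reporter, with a stated time of 24 h, tested at 50 uM; on this read-out higher numbers stand for a stronger effect at the one concentration tested and lower numbers for a weaker effect. Compound 1 `Cc1cc(-n2cc(C(=O)Nc3cc(F)cc(F)c3)c(=O)c3ccc(N(C)C)nc32)ccc1OCCCCCCC[N+]12CCN(CC1)CC2` gives 20.8%. Its isomer compound 2 `Cc1cc(OCCCCCCC[N+]23CCN(CC2)CC3)cc(-n2cc(C(=O)Nc3cc(F)cc(F)c3)c(=O)c3ccc(N(C)C)nc32)c1`, built from the same atoms joined differently, gives 5.52%; the difference between the two cores is not broken down here. Compound 3 `Cc1cc(-n2cc(C(=O)Nc3cc(F)cc(F)c3)c(=O)c3ccc(N(C)C)nc32)ccc1OCCCCCCC[N+]1(C)CCCC1` gives 35.9%.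

Compounds 1 and 3 differ in one place, (a group of 6 heavy atoms (5 carbon, 1 nitrogen; one five-membered non-aromatic ring with 1 hetero atom) in place of a group of 8 heavy atoms (6 carbon, 2 nitrogen; 2 six-membered non-aromatic rings with 2 hetero atoms each), on a saturated chain carbon, seven bonds along the chain from an oxygen on an aromatic ring), and the step of a number 15.1 percentage points higher from compound 1 to compound 3 (beyond the scatter). Compound 2 stands lowest of the three numbers, with compound 1 and compound 3 both beyond the scatter above it.

Compound 4 `Cc1cc(OCCCCCCC[N+]2(C)CCCC2)cc(-n2cc(C(=O)Nc3cc(F)cc(F)c3)c(=O)c3ccc(N(C)C)nc32)c1` has not yet been measured in this assay. It carries the same change relative to compound 2 that compound 3 carries relative to compound 1: a group of 6 heavy atoms (5 carbon, 1 nitrogen; one five-membered non-aromatic ring with 1 hetero atom) in place of a group of 8 heavy atoms (6 carbon, 2 nitrogen; 2 six-membered non-aromatic rings with 2 hetero atoms each), on a saturated chain carbon, seven bonds along the chain from an oxygen on an aromatic ring. Within the data shown here, the only guide to what this change does is the single pair of compound 1 and compound 3, where the step of a number 15.1 percentage points higher from compound 1 to compound 3 (beyond the scatter) was modest but beyond the scatter. Whether the same gain carries over onto the core of compound 2 is not known from the data; the two cores differ by an unbroken-down rearrangement and compound 2 starts from a lower number.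

On that basis compound 4 is expected to move by about a number 13.5 percentage points higher from compound 2 to compound 4 (beyond the scatter) relative to compound 2, a step of the same kind as the measured one but with wider uncertainty. The estimate for compound 4 in this assay is 19%, with a plausible range from 5% to 35%.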

Compound 4, a percentage reported as inhibition, at one concentration (the size of the read-out at that concentration, not a potency): 35.4%
Estimate against measurement, compound 4: 16.4 percentage points below; the measured number lies above the stated range.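

On the core of compound 2, the group of 6 heavy atoms in place of the group of 8 heavy atoms, on the same saturated chain carbon, gives in this assay a number 29.9 percentage points higher from compound 2 to compound 4 (beyond the scatter), so the direction seen on the core of compound 1 carries over. The size of the step does not carry over, and the gain read from one core is a poor guide to the size of the gain on the other: the same change on two cores in this assay, a number 15.1 percentage points higher (beyond the scatter) from compound 1 to compound 3 and a number 29.9 percentage points higher (beyond the scatter) from compound 2 to compound 4, 14.8 percentage points apart, beyond the scatter of two such steps. With one pair on each of two cores, these numbers show that the core can matter for the size of this step, but they do not show how the size depends on the core or why the gap arises, and a read-out at one concentration gives no potency for either pair.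

The compounds shown leave open whether the direction holds on further cores and for other charged groups at the end of the chain, such as trimethylammonium or a six-membered piperidinium ring. They also leave open what an uncharged tertiary amine in the same place, or a shorter or longer chain carrying either group, would do to the size of the step.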